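The compounds below may be only part of what the source reports. "The series", "measured", "known", "first", "only" and "open" are said of these compounds alone.

Compounds measured so far in a functional assay on SMMC-7721 cells (Homo sapiens) for inhibition, read by CCK-8 assay; on this read-out higher numbers stand for weaker inhibition and lower numbers for stronger inhibition:
- compound 1 `Oc1ccccc1/C=N/c1nnc(SCc2nnc(-c3ccc(F)cc3)o2)s1`: 13100 nM
- compound 2 `Cc1ccccc1-c1nnc(CSc2nnc(/N=C/c3ccccc3O)s2)o1`: 15500 nM
- compound 3 `Cc1cccc(-c2nnc(CSc3nnc(/N=C/c4ccccc4O)s3)o2)c1`: 4550 nM

All three share one core and differ only in the aryl group on the five-membered ring. Compound 3 gives the lowest number of the three and its steps to both others lie beyond the scatter, so it is the strongest inhibitor of the set: a 2.9-fold lower number from compound 1 to compound 3 (0.46 log units; beyond the scatter) and a 3.4-fold lower number from compound 2 to compound 3 (0.53 log units; beyond the scatter). Between compound 1 and compound 2 the change is a 1.2-fold higher number from compound 1 to compound 2 (0.07 log units; within the scatter).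

Compound 4 `COc1ccc(-c2nnc(CSc3nnc(/N=C/c4ccccc4O)s3)o2)cc1` is not yet measured. Relative to compound 3 the change is 4-methoxyphenyl in place of 3-methylphenyl on an aromatic carbon. For the measured compounds named here, no measured step involves a methoxy group, so the expectation rests only on the aryl swaps at this position. Both measured swaps away from 3-methylphenyl gave modest rises in the number; a further change of the aryl group is therefore expected to give, if anything, a modest rise, with a 2.0-fold higher number from compound 3 to compound 4 (0.30 log units; within the scatter) as the working guess. Compound 4 is expected to give about 9000 nM in this assay, with a range from 3000 nM to 27000 nM.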

Compound 4, half-maximal inhibitory concentration: 10000 nM
Estimate against measurement, compound 4: 1.1-fold (0.05 log units) below; the measured number falls inside the stated range.
By their numbers in this assay, from the lowest: compound 3; then compounds 4, 1 and 2 (each within the scatter of the next).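

In this assay, 4-methoxyphenyl is a further aryl group at this position that does not match 3-methylphenyl (a 2.2-fold higher number from compound 3 to compound 4 (0.34 log units; beyond the scatter)), so compound 3 now stands as the strongest inhibitor of four compounds rather than three. The new group cannot be separated from the other two aryl groups (a 1.6-fold lower number from compound 2 to compound 4 (0.19 log units; within the scatter); a 1.3-fold lower number from compound 1 to compound 4 (0.12 log units; within the scatter)), which leaves 4-fluorophenyl, 2-methylphenyl and 4-methoxyphenyl within the scatter of one another, with 3-methylphenyl alone apart. Nothing available explains why 3-methylphenyl stands apart.

Still open, going by these compounds, is how an aryl group carrying an amine or a carboxylic acid would read at this position. Also open, on these data alone, is whether any change elsewhere on the shared core moves the number more than these aryl swaps do.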